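Chloro for Propoxy on the Amide-Bearing Ring

A few compounds are considered here, and "the series" means these few. Any claim that something is new, unique, unknown or untested is made for them only; others in the source may bear on it.

Measured so far:
- compound 1, `CCCOc1ccc(NC(=O)CCCCCCCSc2nnc(Cc3nn(C)c(=O)c4ccccc34)n2C)cc1`: 1600 nM
- compound 2, `CC(C)COc1ccc(NC(=O)CSc2nnc(Cc3nn(C)c(=O)c4ccccc34)n2C)cc1`: 30000 nM

In an assay on isolated protein (Mus musculus) for inhibition of IL15-IL15 receptor (Homo sapiens), read by resazurin assay, with stated times of 30 min and 2.5 days (on this read-out lower numbers stand for stronger inhibition and higher numbers for weaker inhibition), compound 1 gives the lower of the two numbers; compound 2 gives a number that lies well beyond the usual scatter above it. Compound 2 differs from compound 1 in more than one place, so the two values alone cannot be assigned to any single change.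

Compound 3, `Cn1c(Cc2nn(C)c(=O)c3ccccc23)nnc1SCCCCCCCC(=O)Nc1ccc(Cl)cc1`, differs from compound 1 in one place: chloro in place of propoxy on an aromatic carbon. The shared core and the long chain of compound 1 are kept. Going by the values given here, no measured pair in this set isolates this change, so the size of its effect is open. A modest step is expected, if any, with no clear direction beyond the scatter; the step estimated from compound 1 to compound 3 is a 1.6-fold higher number from compound 1 to compound 3 (0.19 log units; within the scatter). Compound 3 is expected to give about 2500 nM, with a plausible range from 800 nM to 8000 nM.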

Compound 3, half-maximal inhibitory concentration: 800 nM
Estimate against measurement, compound 3: 3.1-fold (0.49 log units) above, and the stated range covers the measured number.
By their numbers in this assay, from the lowest: compounds 3 and 1 (each within the scatter of the next); then compound 2.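

In this assay, chloro in place of propoxy gives a 2.0-fold lower number from compound 1 to compound 3 (0.30 log units; within the scatter) on this first step in the set that changes one place only. On the ring that carries the amide nitrogen, one heavy atom can therefore stand in for four, and the hydrogen-bond acceptor of the propoxy group can go, with no change that this read-out can separate from scatter. Nothing at hand explains why these two groups read alike.

From the compounds shown here alone, whether other groups at this place, such as an amine, a carboxylic acid or a longer alkoxy chain, would also read alike remains open. How much the long chain contributes also cannot be read, as compound 2 differs from compound 1 and compound 3 in more than one place.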